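A Cyclopropyl Cap in Place of Methoxymethyl on Compound 1

The source may hold more compounds than are shown below. What is called first, only, known or untested is meant among the compounds shown, and "the series" means these compounds.

Of the compounds shown here, three built on a shared core have been tested in a functional assay on HCT-116 cells (Homo sapiens) for inhibition, read by MTT assay, with a stated time of 48 h; on this read-out lower numbers stand for stronger inhibition and higher numbers for weaker inhibition. Compound 1 `COCC(=O)N(Cc1ccc(OC)c(O)c1)c1cc(OC)c(OC)c(OC)c1` gives 230 nM, the lowest number of the three and so the strongest inhibition seen among them. Compound 3 `C/C=C/C(=O)N(Cc1ccc(OC)c(F)c1)c1cc(OC)c(OC)c(OC)c1` gives 1160 nM, and compound 2 `COc1ccc(CNc2cc(OC)c(OC)c(OC)c2)cc1Br` gives 48100 nM; both of these gaps from compound 1 lie beyond the usual scatter of repeated measurements. No two of these three compounds differ in only one place, so nothing here isolates the effect of any single change.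

Compound 4 `COc1ccc(CN(C(=O)C2CC2)c2cc(OC)c(OC)c(OC)c2)cc1O` has not yet been measured. It differs from compound 1 in one place: cyclopropyl in place of methoxymethyl on a carbonyl carbon. The group that leaves and the group that enters are of like size, and everything else in compound 1 stays as it was.

Within the data shown here, with no measured step of this kind to lean on, only a modest effect is expected. The step of a 1.3-fold higher number from compound 1 to compound 4 (0.12 log units; within the scatter) is estimated to be small, within the scatter or only slightly beyond it, in either direction. The estimate for compound 4 in this assay is 300 nM, with a range from 100 nM to 1000 nM.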

Compound 4, half-maximal inhibitory concentration: 49 nM
Compound 4: the middle estimate sits 6.1-fold (0.79 log units) above what was measured; measured number outside the range, below it.
By their numbers in this assay, from the lowest: compound 4; then compound 1; then compound 3; then compound 2.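

Among these compounds, until now, no two compounds differed in only one place, so the group on the carbonyl carbon had no measured effect of its own. In this assay, cyclopropyl in place of methoxymethyl gives a 4.7-fold lower number from compound 1 to compound 4 (0.67 log units; beyond the scatter), so this position responds clearly to a swap between two groups with the same count of heavy atoms. The step also shows that, on the core of compound 1, the oxygen of methoxymethyl, the group's one hydrogen-bond acceptor, is not needed for a low number, but no measurement on hand explains why the number falls.

This single step cannot tell whether the gain comes from having a ring or simply from losing the oxygen; an isopropyl group, a cyclobutyl ring or a plain ethyl chain on the same carbonyl carbon would help separate those two readings. It also leaves open whether the same swap would give a similar step on other members of the series, since compound 2 and compound 3 each differ from compound 4 in more than one place.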